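A few compounds are considered here, and "the series" means these few. Any claim that something is new, unique, unknown or untested is made for them only; others in the source may bear on it.

Measured so far in a functional assay on HEK293 cells for agonist activity at Bile acid receptor (Homo sapiens); on this read-out higher numbers stand for larger maximal responses and lower numbers for smaller maximal responses:
compound 1, `CN(Cc1cccc(C(=O)O)c1)c1ccc(OCc2c(-c3c(Cl)cccc3Cl)noc2C2CC2)nc1C(F)(F)F`, gives 79%
compound 2, `CC(Nc1ccc(C(=O)O)cc1)c1ccc(OCc2c(-c3c(Cl)cccc3Cl)noc2C2CC2)nc1C(F)(F)F`, gives 59%

Among the compounds with values here, compound 2 stands at the lower of the two numbers in this assay; the single measured step shows a number 20 percentage points lower from compound 1 to compound 2 (beyond the scatter), and that difference lies beyond the scatter. Compound 3, `O=C(O)c1cccc(OCc2ccc(OCc3c(-c4c(Cl)cccc4Cl)noc3C3CC3)nc2C(F)(F)F)c1`, is not yet measured. It differs from compound 2 by (3-carboxyphenoxy)methyl in place of 1-((4-carboxyphenyl)amino)ethyl on an aromatic carbon. Within the data shown here, the only measured step that bears on it is the one from compound 1 to compound 2, where the carboxyphenyl-bearing group on the shared core was exchanged and a modest drop followed. Among the measured compounds shown here, the exchange leading to compound 3 again replaces that same group, and the entering group carries its carboxy in the 3-position, as the group in compound 1 does, so a modest rise back toward compound 1 is expected, with wide uncertainty because no measured pair contains the phenoxymethyl link. Compound 3 is therefore expected to give 70%, between 50% and 90%, an estimated step of a number 11 percentage points higher from compound 2 to compound 3 (beyond the scatter).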

Compound 3, largest response reached (reported as efficacy), in percent of the reference or control that the assay uses: 62%
Compound 3: the middle estimate sits 8 percentage points above what was measured; the measured number falls inside the stated range.
By their numbers in this assay, from the lowest: compounds 2 and 3 (each within the scatter of the next); then compound 1.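

In this assay, placing (3-carboxyphenoxy)methyl in place of 1-((4-carboxyphenyl)amino)ethyl on this aromatic carbon gives a number 3 percentage points higher from compound 2 to compound 3 (within the scatter) and so leaves the maximal response unchanged. The entering group has its carboxy in the 3-position, as the group in compound 1 does, yet the comparison with that compound gives a number 17 percentage points lower from compound 1 to compound 3 (beyond the scatter), so a 3-carboxy group on the ring does not by itself keep the response of compound 1. No measured evidence accounts for either step.

The compounds shown leave open whether the response of compound 1 depends on the nitrogen of its (3-carboxybenzyl)(methyl)amino group or on that group's methyl. Also open, on these data alone, is how a (4-carboxyphenoxy)methyl group would read, and whether an amide could stand in place of the carboxylic acid.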